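The source may report more compounds than this note shows. Statements on the series, on what has been measured and on what is new or still open speak of the compounds shown alone.

Compound 1 `CNC(=O)/C(C)=C/c1ccc(NC(=O)Nc2ccc(Cl)c(C(F)(F)F)c2)cc1` in a functional assay on HT-29 cells (Homo sapiens) for inhibition, read by MTT assay, with a stated time of 120 h (on this read-out lower numbers stand for stronger inhibition and higher numbers for weaker inhibition), gives only a limit, > 50000 nM, so its position on the numbers is not fixed. Compound 2 `C/C(=C\c1ccc(NC(=O)Nc2ccc(Cl)c(C(F)(F)F)c2)cc1)C(=O)N1CC(C)OC(C)C1` in this assay likewise gives a limit, > 50000 nM. The step that the two limits leave unreadable from compound 1 to compound 2, 2,6-dimethylmorpholin-4-yl in place of methylamino on a carbonyl carbon, is therefore not readable; the limit of > 50000 nM in this assay, at which 2 of the 2 values shown sit, is all the evidence the series holds. Compound 3 `CNC(=O)c1cccc(-c2ccc(NC(=O)Nc3ccc(Cl)c(C(F)(F)F)c3)cc2)c1` differs from compound 1 by 3-(methylcarbamoyl)phenyl in place of 2-(methylcarbamoyl)prop-1-en-1-yl on an aromatic carbon. Among the measured compounds shown here, no measured step bears on this change. Compound 3 is expected to give 30000 nM, range 5000 nM to 100000 nM, most likely a limit again. The step of an at least 1.6-fold lower number from compound 1 to compound 3 (0.22 log units; that floor lies within the scatter) is expected to stay unreadable.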

Compound 3, half-maximal inhibitory concentration: 29300 nM
Compound 3: middle estimate off by 1.0-fold (0.01 log units), on the high side; the measured number falls inside the stated range.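

In this assay, among the compounds shown here, compound 3 gives the first value that is a number and not a limit. Placing 3-(methylcarbamoyl)phenyl on this aromatic carbon in place of 2-(methylcarbamoyl)prop-1-en-1-yl gives an at least 1.7-fold lower number from compound 1 to compound 3 (0.23 log units; that floor lies within the scatter), so only a floor is readable and no gain beyond the scatter is established. The step between compound 1 and compound 2 cannot be read, and the other values remain limits: the limit of > 50000 nM in this assay, at which 2 of the 3 values shown sit.

Left open is what a carboxylic acid or an amine in place of the methylcarbamoyl group would give. Also open, from the compounds shown here alone, is whether an unsubstituted phenyl at this position would give a value like that of compound 3.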